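Adding an Amino Group to Compound 2: An Expected Result

The source may report more compounds than this note shows. Statements on the series, on what has been measured and on what is new or still open speak of the compounds shown alone.

Measured compounds in a functional assay on HeLa S3 cells (Homo sapiens) for antiproliferative activity, read by XTT assay, with a stated time of 72 h; on this read-out lower numbers stand for stronger inhibition and higher numbers for weaker inhibition:
compound 1 `COc1ncnc2c1c(-c1cccs1)cn2[C@@H]1O[C@H](CO)[C@@H](O)[C@H]1O` gives 1760 nM;
compound 2 `COc1ncnc2c1c(-c1ccco1)cn2[C@@H]1O[C@H](CO)[C@@H](O)[C@H]1O` gives 1020 nM;
compound 3 `CNc1ncnc2c1c(-c1ccco1)cn2[C@@H]1O[C@H](CO)[C@@H](O)[C@H]1O` gives 5000 nM.

Compound 2 shows the lowest number of the three. Its nearest neighbour is compound 1, a 1.7-fold lower number from compound 1 to compound 2 (0.24 log units; within the scatter); the furthest is compound 3, a 4.9-fold higher number from compound 2 to compound 3 (0.69 log units; beyond the scatter).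

Compound 4 `COc1nc(N)nc2c1c(-c1ccco1)cn2[C@@H]1O[C@H](CO)[C@@H](O)[C@H]1O` differs from compound 2 by amino in place of hydrogen on an aromatic carbon. Neither measured step touches this position: one swaps the five-membered ring, the other swaps methoxy for methylamino. Both were modest or within the scatter, so a step of modest size is expected here too, with no clear direction from the data. Compound 4 is estimated at 3000 nM, in the range 800 nM to 12000 nM, meaning an expected 2.9-fold higher number from compound 2 to compound 4 (0.47 log units; beyond the scatter) in this assay.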

Compound 4, half-maximal inhibitory concentration: > 20000 nM
Compound 4: only a limit was reported (the forecaster's own chance of this, stated with the estimate: 15%); at least 6.6-fold (0.82 log units) between middle value and limit.
By their numbers in this assay, from the lowest: compounds 2 and 1 (each within the scatter of the next); then compound 3. At a limit, above all of these: compound 4.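

In this assay, the position between two ring nitrogen atoms proves sensitive: amino in place of hydrogen there gives an at least 19-fold higher number from compound 2 to compound 4 (1.29 log units; beyond the scatter). This one added heavy atom moves the read-out further than either earlier change, the swap of the five-membered ring or of methoxy for methylamino. For compound 4 the reading is a limit and not a number: the limit of > 20000 nM in this assay, at which 1 of the 4 values shown sits.

Going by these compounds, whether another group at this position, such as methyl or a chlorine atom, weakens the read-out as much remains open. On these data alone, it is also open whether amino acts the same way with thiophen-2-yl in place of furan-2-yl.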